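Naphthyl sulfonamide in place of diaminophenyl on a quinazoline

A few compounds are considered here, and "the series" means these few. Any claim that something is new, unique, unknown or untested is made for them only; others in the source may bear on it.

Compound 2 `COc1cc2nc(N3CCN(S(=O)(=O)c4ccc(N)cc4N)CC3)nc(N)c2cc1OC` is measured in a functional assay on PC-3 cells (Homo sapiens) for inhibition (on this read-out lower numbers stand for stronger inhibition and higher numbers for weaker inhibition), where compound 2 gives 67000 nM, the highest of the two numbers in hand. Within the data shown here, its only neighbour is compound 1 `COc1cc2nc(N3CCN(S(=O)(=O)c4ccc(Br)cc4)CC3)nc(N)c2cc1OC`, which in this assay gives 20000 nM; the step of a 3.4-fold higher number from compound 1 to compound 2 (0.53 log units; beyond the scatter) is the one measured change at the sulfonyl sulfur. Compound 3 `COc1cc2nc(N3CCN(S(=O)(=O)c4cccc5ccccc45)CC3)nc(N)c2cc1OC` differs from compound 2 in that (naphthalen-1-yl in place of 2,4-diaminophenyl on a sulfonyl sulfur). The new group, like the 4-bromophenyl of compound 1, carries no hydrogen-bond donors or acceptors, so the measured step is the closest guide, read in reverse. Compound 3 is therefore expected to move back toward compound 1, with a step of a 3.7-fold lower number from compound 2 to compound 3 (0.57 log units; beyond the scatter) in this assay beyond the scatter and toward a lower number. The estimate for compound 3 in this assay is 18000 nM, with a range from 5000 nM to 60000 nM.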

Compound 3, half-maximal inhibitory concentration: 14000 nM
The estimate for compound 3 lay 1.3-fold (0.11 log units) above the measured number; the range from low to high includes it.
By their numbers in this assay, from the lowest: compounds 3 and 1 (each within the scatter of the next); then compound 2.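

In this assay, the change to naphthalen-1-yl on the sulfonyl sulfur gives a 4.8-fold lower number from compound 2 to compound 3 (0.68 log units; beyond the scatter) and so shows that the number of compound 2 can be reversed by a group with 2 six-membered aromatic rings of carbon only. Against the 4-bromophenyl group, the same group gives a 1.4-fold lower number from compound 1 to compound 3 (0.15 log units; within the scatter) and so adds a second aromatic ring without a step that stands out from repeat measurements; of the three compounds, compound 2 alone stands apart, and it alone carries amine groups on its aryl ring. No measurement in hand accounts for these steps. Still open, going by these compounds, is whether a single amine on the phenyl ring would give a number like that of compound 2. Open too, on these data alone, is how a carboxylic acid or a plain phenyl on the sulfonyl sulfur would compare.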